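Carbonyl substituent exchange at the shared core

The compounds below may be only part of what the source reports. "The series", "measured", "known", "first", "only" and "open" are said of these compounds alone.

Compound 3 `COc1cc(-c2nn(-c3cccc(NC(=O)Nc4cccc(C(F)(F)F)c4)c3)cc2-c2ccncc2)ccc1Cl` gives 754 nM in a functional assay on M14 cells (Homo sapiens) for inhibition, read by sulforhodamine B assay, with a stated time of 48 h (on this read-out lower numbers stand for stronger inhibition of growth and higher numbers for weaker inhibition of growth), the lowest of the three numbers shown. Compound 2 `COc1cc(-c2nn(-c3cccc(NC(=O)Nc4ccc(Cl)c(Cl)c4)c3)cc2-c2ccncc2)ccc1Cl` gives 911 nM and compound 1 `O=C(Nc1cccc(-n2cc(-c3ccncc3)c(-c3ccc(Cl)c(O)c3)n2)c1)Nc1cccc(C(F)(F)F)c1` gives 1400 nM; the steps of a 1.2-fold lower number from compound 2 to compound 3 (0.08 log units; within the scatter) and a 1.9-fold lower number from compound 1 to compound 3 (0.27 log units; within the scatter) both stay within the scatter. Compound 4 `COc1cc(-c2nn(-c3cccc(NC(=O)c4ccccc4)c3)cc2-c2ccncc2)ccc1Cl` differs from compound 3 by phenyl in place of (3-(trifluoromethyl)phenyl)amino on a carbonyl carbon. Neither measured step bears directly on this change: one varies the aryl group on the amide-type nitrogen, the other the substituent on the oxygen on an aromatic ring, and nothing measured here tests an exchange at the carbonyl carbon. For compound 4 a step of a 3.3-fold higher number from compound 3 to compound 4 (0.52 log units; beyond the scatter) toward a higher number is expected, with a broad range. Compound 4 is estimated at 2500 nM, between 700 nM and 9000 nM.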

Compound 4, concentration for 50% growth inhibition: 575 nM
For compound 4 the middle estimate is 4.3-fold (0.64 log units) above the measured one; measured number below the stated range.
By their numbers in this assay, from the lowest: compounds 4, 3, 2 and 1 (each within the scatter of the next, the first and the last beyond it).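

At the carbonyl carbon, the steps of a 1.3-fold lower number from compound 3 to compound 4 (0.12 log units; within the scatter) and a 1.6-fold lower number from compound 2 to compound 4 (0.20 log units; within the scatter) both stay within the scatter in this assay. Thus, on the shared core, phenyl can stand in place of either arylamino group, with the loss of the amino nitrogen and its hydrogen-bond donor, without a step beyond the scatter. No supporting data bear on why this exchange is tolerated. Open, from the compounds shown here alone, is whether a cyclohexyl or methyl group on the carbonyl carbon, or a phenyl carrying a carboxylic acid or an amine, also stays within the scatter.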